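This account rests on a few compounds, and the source may have more. Where it says the series, first, only, none or still open, it means among the compounds named here.

Compound 2 `CCCCCCNc1nc(SCCCC)nc2ncccc12` stands at 1200 nM in a functional assay on MDA-MB-231 cells (Homo sapiens) for cytotoxicity, read by neutral red uptake, with a stated time of 72 h (a higher number here means a weaker inhibitor, a lower number a stronger inhibitor), and its only comparator, compound 1 `CCCCCCNc1nc(SCC)nc2ncccc12`, gives 1400 nM. For the measured compounds named here, the one measured step, a 1.2-fold lower number from compound 1 to compound 2 (0.07 log units; within the scatter), changed nothing that the assay can resolve. Compound 3 `CCCCCCNc1nc(SCCCCC)nc2ncccc12` differs from compound 2 by methyl in place of hydrogen on a saturated chain carbon, four bonds along the chain from a sulfur, the same kind of chain growth carried one carbon further. Because that earlier growth a 1.2-fold lower number from compound 1 to compound 2 (0.07 log units; within the scatter) stayed within the scatter, the expected step of a 1.1-fold lower number from compound 2 to compound 3 (0.04 log units; within the scatter) is small, with no clear direction. Compound 3 is therefore estimated at 1100 nM, in a range from 550 nM to 2200 nM.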

Compound 3, half-maximal inhibitory concentration: 9000 nM
Beside the measured number, compound 3's estimate is 8.2-fold (0.91 log units) below it; the measured number lies above the stated range.
By their numbers in this assay, from the lowest: compounds 2 and 1 (each within the scatter of the next); then compound 3.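

Chain length on the sulfur does matter in this assay: methyl in place of hydrogen, four bonds along the chain from a sulfur, gives a 7.5-fold higher number from compound 2 to compound 3 (0.88 log units; beyond the scatter), although the earlier growth stayed within the scatter. Measured from the shorter ethyl chain, the change is a 6.4-fold higher number from compound 1 to compound 3 (0.81 log units; beyond the scatter), so across these three compounds the weakening appears only at the last step. Nothing measured here explains this jump. Still open, on these data alone, is whether a hexyl chain on the sulfur weakens the compound further, and how a chain ending in an amine or a carboxylic acid behaves.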